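Ethoxy added to the pyridin-3-yl arm of compound 3

The source may report more compounds than this note shows. Statements on the series, on what has been measured and on what is new or still open speak of the compounds shown alone.

Measured so far in a functional assay on BJAB cells (Homo sapiens) for antiproliferative activity, with a stated time of 4 days; on this read-out lower numbers stand for an effect already at smaller amounts and higher numbers for an effect only at larger amounts of compound:
compound 1 `CNc1cc(-c2c(C)nn(-c3nc(-c4ccc(Cl)c(Cl)c4)c(SC(C)C)s3)c2C(=O)O)ccn1` gives 18000 nM
compound 2 `Cc1nn(-c2nc(-c3ccc(Cl)c(Cl)c3)c(SC(C)C)s2)c(C(=O)O)c1-c1ccccc1Cl` gives 13100 nM
compound 3 `Cc1nn(-c2nc(-c3ccc(Cl)c(Cl)c3)c(SC(C)C)s2)c(C(=O)O)c1-c1cccnc1` gives 12000 nM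

Compound 3 shows the lowest number of the three, but its gaps to compound 2 and compound 1 both lie within the scatter, so the three are not separated in this assay. Compound 4 `CCOc1ncccc1-c1c(C)nn(-c2nc(-c3ccc(Cl)c(Cl)c3)c(SC(C)C)s2)c1C(=O)O` differs from compound 3 by ethoxy in place of hydrogen on an aromatic carbon. The measured steps at this position each swap the whole aryl group: a 1.4-fold lower number from compound 1 to compound 2 (0.14 log units; within the scatter), a 1.5-fold lower number from compound 1 to compound 3 (0.18 log units; within the scatter), a 1.1-fold lower number from compound 2 to compound 3 (0.04 log units; within the scatter), all within the scatter. Going by the values given here, no measured step adds a group onto a pyridin-3-yl. With nothing pointing either way, no step beyond the scatter is expected in this assay. Compound 4 is estimated at 12000 nM, range 6000 nM to 25000 nM, an expected no change at the digits printed from compound 3 to compound 4 (within the scatter).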

Compound 4, half-maximal effective concentration: 11000 nM
Compound 4: the middle estimate sits 1.1-fold (0.04 log units) above what was measured; low and high end bracket the measured number.
By their numbers in this assay, from the lowest: compounds 4, 3, 2 and 1 (each within the scatter of the next).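

In this assay the pyridin-3-yl arm accepts ethoxy on the aromatic carbon next to the ring nitrogen, ortho to a large group, without a step beyond the scatter (a 1.1-fold lower number from compound 3 to compound 4 (0.04 log units; within the scatter)). The 2-ethoxypyridin-3-yl arm is also not separated from the other two aryl groups (a 1.2-fold lower number from compound 2 to compound 4 (0.08 log units; within the scatter); a 1.6-fold lower number from compound 1 to compound 4 (0.21 log units; within the scatter)). No available evidence bears on this result.

As far as these compounds go, whether a longer alkoxy chain such as butoxy, or a morpholine ring, at this carbon would give a step beyond the scatter remains open. Also open, from the compounds shown here alone, is whether any group on this arm moves the number at all.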